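A few compounds are considered here, and "the series" means these few. Any claim that something is new, unique, unknown or untested is made for them only; others in the source may bear on it.

Compounds measured so far:
compound 1, `Cc1ccccc1-n1nncc1CN1C(=O)C2(C(C#N)=C(N)Oc3c2c2nc4ccccc4nc2c2ccccc32)c2ccccc21` — in a functional assay on HepG2 cells (Homo sapiens) for antiproliferative activity, read by MTT assay, with a stated time of 48 h (a higher number here means a weaker inhibitor, a lower number a stronger inhibitor), compound 1 gives > 50000 nM, a limit of the assay and not a number.
compound 2, `CC(=O)Nc1ccc(-n2nncc2CN2C(=O)C3(C(C#N)=C(N)Oc4c3c3nc5ccccc5nc3c3ccccc43)c3ccccc32)cc1` — in this assay compound 2 gives > 50000 nM, again a limit of the assay and not a number.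

Compound 2 therefore stands only at a limit in this assay, and the other value in the series is a limit as well (the limit of > 50000 nM in this assay, at which 2 of the 2 values shown sit). Among the compounds with values here, the one measured step, a step that the two limits leave unreadable from compound 1 to compound 2, cannot be read for the same reason.

Compound 3, `Cc1ccc(-n2nncc2CN2C(=O)C3(C(C#N)=C(N)Oc4c3c3nc5ccccc5nc3c3ccccc43)c3ccccc32)c(C)c1`, keeps the shared core and changes only the group on the aromatic nitrogen: 2,4-dimethylphenyl in place of 4-acetamidophenyl on an aromatic nitrogen.

Within the data shown here, the step from compound 1 to compound 2 is the only measured comparison that bears on a change at this position, and it gives no readable size. With both measured compounds at the limit and a change of similar kind, no step beyond the scatter can be expected, and compound 3 is expected to sit at the limit too, so that a step that the limit leaves unreadable from compound 2 to compound 3 is the estimated step. The estimate for compound 3 in this assay is 70000 nM, with a range from 20000 nM to 250000 nM.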

Compound 3, half-maximal inhibitory concentration: > 50000 nM
Compound 3: only a limit was reported; the forecaster's own chance of this, stated with the estimate: 85%; the middle value is on the limit's open side.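

In this assay, within the data shown here, compound 3 gives > 50000 nM, a limit of the assay and not a number, so no step from compound 1 or compound 2 to compound 3 can be read. The three compounds share one limit: the limit of > 50000 nM in this assay, at which 3 of the 3 values shown sit. The compounds shown leave open whether 2-methylphenyl, 4-acetamidophenyl and 2,4-dimethylphenyl differ from one another in this assay.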